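This account rests on a few compounds, and the source may have more. Where it says the series, first, only, none or still open, it means among the compounds named here.

Working notes on the series. For the measured compounds named here, compound 3 `COc1cc2c(cc1OC)CN(CCCCCC(=O)c1c(C)c(OC)c(OC)c(OC)c1OC)CC2` gives 0.38 nM in an assay on membranes from liver for displacement of a labelled ligand from Sigma intracellular receptor 2 (Rattus norvegicus), read by scintillation counting, with a stated time of 120 min (on this read-out higher numbers stand for weaker inhibition and lower numbers for stronger inhibition), the lowest number of the three measured so far, and its steps to both other compounds lie beyond the scatter. Compound 2 `COc1cc2c(cc1OC)CN(CCCCC(=O)c1c(C)c(OC)c(OC)c(OC)c1OC)CC2` gives 3 nM in this assay, and compound 1 `COc1cc2c(c(OC)c1OC)CCN(CCC(=O)c1c(C)c(OC)c(OC)c(OC)c1OC)C2` gives 11500 nM, the highest number of the set; compound 1 differs from compound 3 in more than one place, so its value cannot be tied to any single change. Compound 4 `COc1cc2c(c(OC)c1OC)CCN(CCCCCC(=O)c1c(C)c(OC)c(OC)c(OC)c1OC)C2` carries the same six-carbon chain as compound 3 and differs from it only by methoxy in place of hydrogen on an aromatic carbon. Going by the values given here, no measured pair isolates this change, and the only compound bearing the added methoxy, compound 1, also carries a shorter chain. The expectation is therefore a step from compound 3 to compound 4 of a 2.6-fold higher number from compound 3 to compound 4 (0.42 log units; beyond the scatter), small and of uncertain direction, possibly within the scatter. Compound 4 is estimated at 1 nM in this assay, with a range from 0.2 nM to 8 nM.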

Compound 4, inhibition constant: 19.7 nM
Compound 4: middle estimate off by 20-fold (1.29 log units), on the low side; measured number outside the range, above it.
By their numbers in this assay, from the lowest: compound 3; then compound 2; then compound 4; then compound 1.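

With the chain held constant, the added methoxy can now be read alone: a 52-fold higher number from compound 3 to compound 4 (1.71 log units; beyond the scatter) in this assay, a large step for a small substituent on the aromatic carbon ortho to a methoxy group. The earlier compounds shown here could not show this, as the only one bearing this methoxy, compound 1, also carried a shorter chain, so this position is clearly not indifferent to substitution. Among the two compounds with the methoxy, the one with the longer chain has the lower number, compound 4 at 19.7 nM against compound 1 at 11500 nM, so chain length still matters with this group in place.

Open, from the compounds shown here alone, is whether a smaller group such as fluorine, or a hydroxyl or ethoxy, at this position would cost as much, and whether a longer chain would recover the loss. No measurement shown bears on why the methoxy has this effect.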